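This account rests on a few compounds, and the source may have more. Where it says the series, first, only, none or still open, it means among the compounds named here.

Measured compounds:
Compound 1, `c1ccc(C2=NN(C3=NC(c4ccccc4)CS3)C(c3cccc4ccccc34)C2)cc1`: in a functional assay on BGC-823 cells (Homo sapiens) for inhibition, read by CCK-8 assay, with a stated time of 48 h (on this read-out lower numbers stand for stronger inhibition and higher numbers for weaker inhibition), compound 1 gives 14300 nM.
Compound 2, `Cc1ccc(C2=NN(C3=NC(c4ccccc4)CS3)C(c3cccc4ccccc34)C2)cc1`: in this assay compound 2 gives 13300 nM.

Compound 2 has the lower of the two numbers, but the step of a 1.1-fold lower number from compound 1 to compound 2 (0.03 log units; within the scatter) lies within the scatter, so the two compounds cannot be ordered on this evidence. Compound 3, `Clc1ccc(C2=NN(C3=NC(c4ccccc4)CS3)C(c3cccc4ccccc34)C2)cc1`, is not yet measured; it differs from compound 2 by chloro in place of methyl on an aromatic carbon. Among the compounds with values here, the only measured step at this position, a 1.1-fold lower number from compound 1 to compound 2 (0.03 log units; within the scatter), concerns a different exchange and stayed within the scatter; no measured step exchanges methyl for chloro, so the direction of that change is unknown. Within the data shown here, since the one available step at this position did not move the number beyond the scatter, the expected step is a 1.1-fold lower number from compound 2 to compound 3 (0.04 log units; within the scatter). Compound 3 is therefore estimated at 12000 nM, with a range from 5000 nM to 30000 nM.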

Compound 3, half-maximal inhibitory concentration: 19600 nM
Compound 3: the middle estimate sits 1.6-fold (0.21 log units) below what was measured; measured number inside the range.
By their numbers in this assay, from the lowest: compounds 2, 1 and 3 (each within the scatter of the next).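

With chloro added, this ring carbon, para to a large group, has now carried three different groups, and in this assay the number does not separate any of them. The exchange of methyl for chloro gives a 1.5-fold higher number from compound 2 to compound 3 (0.17 log units; within the scatter) and the exchange of hydrogen for chloro gives a 1.4-fold higher number from compound 1 to compound 3 (0.14 log units; within the scatter) at this same place, so neither chloro exchange moves the number beyond the scatter. No measurement at hand accounts for these numbers.

The three compounds leave open whether a group of another kind at this carbon, such as an amine, a carboxylic acid or a longer chain, would move the number beyond the scatter. They also leave open whether changes elsewhere on the shared core would do so.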